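Methyl to Chloro in a Permeability Pair

This account rests on a few compounds, and the source may have more. Where it says the series, first, only, none or still open, it means among the compounds named here.

In an ADME assay on Caco-2 cells (Homo sapiens) for permeability, read by LC-MS, in the apical to basolateral direction, with a stated time of 2 h, tested at 2 uM (a higher number here means that the compound crosses the layer faster, a lower number that the compound crosses the layer more slowly), compound 1 `CC[C@@H](Nc1c(C#N)c(-c2ccc(-c3ccccc3F)cc2)nc2cnccc12)C(N)=O` gives 140 nm/s and compound 2 `CC[C@@H](Nc1c(C#N)c(-c2ccc(-c3cccc(C)c3F)cc2)nc2cnccc12)C(N)=O` gives 47 nm/s, the lower of the two numbers. For the measured compounds named here, the only measured step is modest: a 3.0-fold lower number from compound 1 to compound 2 (0.47 log units; beyond the scatter), with methyl in place of hydrogen on an aromatic carbon. Compound 3 `CC[C@@H](Nc1c(C#N)c(-c2ccc(-c3cccc(Cl)c3F)cc2)nc2cnccc12)C(N)=O` differs from compound 2 by chloro in place of methyl on an aromatic carbon. The measured step bears on this only indirectly, since it does not exchange these two groups. The expected change in this assay is therefore a 1.3-fold higher number from compound 2 to compound 3 (0.11 log units; within the scatter), with none expected beyond the scatter. For compound 3 the estimate is 60 nm/s, with an expected range of 28 nm/s to 130 nm/s.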

Compound 3, apparent permeability: 39 nm/s
Beside the measured number, compound 3's estimate is 1.5-fold (0.19 log units) above it; the range from low to high includes it.
By their numbers in this assay, from the lowest: compounds 3 and 2 (each within the scatter of the next); then compound 1.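

In this assay, chloro in place of methyl on this aromatic carbon, ortho to a fluoro group, gives a 1.2-fold lower number from compound 2 to compound 3 (0.08 log units; within the scatter), so the two groups cannot be told apart here. Chloro in place of hydrogen gives a 3.6-fold lower number from compound 1 to compound 3 (0.56 log units; beyond the scatter), so the lower number seen with methyl also appears with a second group on this carbon. No evidence is available to explain either step. Going by these compounds, whether an amine or a carboxylic acid on this carbon would stay near compound 2 and compound 3 or come closer to compound 1 remains open.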